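The source may hold more compounds than are shown below. What is called first, only, known or untested is meant among the compounds shown, and "the series" means these compounds.

Of the compounds shown here, two so far carry numbers in a functional assay on MCF7 cells (Homo sapiens) for cytotoxicity, read by MTT assay, with a stated time of 72 h; on this read-out lower numbers stand for stronger inhibition and higher numbers for weaker inhibition. Compound 1 `COc1cccc(/C=C2\CCC/C(=C\c3cc(OC)c(OC)c(OC)c3)C2=O)c1OC` gives 1400 nM. Compound 2 `COc1ccc(/C=C2\CCC/C(=C\c3cccc(Cl)c3)C2=O)cc1OC` gives 6000 nM, the highest of the two numbers, with compound 1 the nearest and the gap between them beyond the usual scatter. Compound 3 `COc1ccc(/C=C2\CCC/C(=C\c3cccc(Br)c3)C2=O)cc1OC` differs from compound 2 by one change: bromo in place of chloro on an aromatic carbon. Among the compounds with values here, no step between measured compounds mirrors this change, so nothing measured speaks to its size. The step expected here is a 1.2-fold lower number from compound 2 to compound 3 (0.08 log units; within the scatter), none beyond the scatter. Compound 3 is estimated at 5000 nM, with a range from 2000 nM to 12000 nM.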

Compound 3, half-maximal inhibitory concentration: 5300 nM
For compound 3 the middle estimate is 1.1-fold (0.03 log units) below the measured one; measured number inside the range.
By their numbers in this assay, from the lowest: compound 1; then compounds 3 and 2 (each within the scatter of the next).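

In this assay, within the data shown here, bromo in place of chloro on this aromatic carbon gives a 1.1-fold lower number from compound 2 to compound 3 (0.05 log units; within the scatter) and is the first single-place step. At this position, the two halogens cannot be told apart in this read-out. No available evidence bears on why this exchange leaves the number within the scatter.

Still open, from the compounds shown here alone, is whether an amine or a carboxylic acid on the same aromatic carbon would give a step beyond the scatter. Going by these compounds, it is also open whether 3-chlorophenyl to 3-bromophenyl behaves alike with other groups on the far ring.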